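Amide replacement of the hydroxy in compound 1

The source may hold more compounds than are shown below. What is called first, only, known or untested is meant among the compounds shown, and "the series" means these compounds.

Compound 1 `COc1cc2c(cc1OC)C(CC(=O)O)CC2` carries a hydroxy on the carbonyl carbon of the shared core. Among the measured compounds shown here, in a functional assay on the whole organism (strain Wistar) for inhibition, with Rattus norvegicus as the target, read by paw edema, with stated times of 60 min and 6 h, at a dose of 100 mg/kg by the oral route (a lower number here means less inhibition, a higher number more inhibition at the dose given (going by the name of the read-out)), compound 1 gives 20.4%, the lowest of the three numbers measured so far. Compound 2 `COc1cc2c(cc1OC)C(CC(=O)NC1CCCCC1)CC2` gives 48.2% in this assay, and compound 3 `COc1cc2c(cc1OC)C(CC(=O)N1CCCCC1)CC2` gives 31.5%. Both replacements of the hydroxy rise beyond the scatter: a number 27.8 percentage points higher from compound 1 to compound 2 (beyond the scatter) and a number 11.1 percentage points higher from compound 1 to compound 3 (beyond the scatter). The two amides also differ between themselves, with a number 16.7 percentage points lower from compound 2 to compound 3 (beyond the scatter).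

Compound 4 `COc1cc2c(cc1OC)C(CC(=O)N1CCOCC1)CC2` is not yet measured. It differs from compound 1 as follows: morpholin-4-yl in place of hydroxy on a carbonyl carbon. Like compound 3, compound 4 carries a six-membered non-aromatic ring on the carbonyl carbon, so the nearest measured step is a number 11.1 percentage points higher from compound 1 to compound 3 (beyond the scatter); the larger step of a number 27.8 percentage points higher from compound 1 to compound 2 (beyond the scatter) belongs to the cyclohexylamino variant and is taken as the upper bound of what is plausible. An increase beyond the scatter is therefore expected in this assay, of a size close to the piperidin-1-yl step rather than the cyclohexylamino step, and the expected step is a number 9.6 percentage points higher from compound 1 to compound 4 (within the scatter). For compound 4 the estimate is 30%, with a range from 15% to 48%.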

Compound 4, a percentage reported as inhibition, in the whole organism at one dose (the size of the read-out at that dose, not a potency): 14.8%
Estimate against measurement, compound 4: 15.2 percentage points above; measured number below the stated range.
By their numbers in this assay, from the lowest: compounds 4 and 1 (each within the scatter of the next); then compound 3; then compound 2.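

Working notes on the carbonyl position. In this assay, morpholin-4-yl in place of hydroxy on the carbonyl carbon gives no separation from the acid (a number 5.6 percentage points lower from compound 1 to compound 4 (within the scatter)), so a rise beyond the scatter is not a general result of amide replacement in this set: compound 2 and compound 3 show it, and compound 4 goes against it. Having a six-membered non-aromatic ring on the carbonyl carbon is also not enough to set the read-out, since the two such rings differ beyond the scatter (a number 16.7 percentage points lower from compound 3 to compound 4 (beyond the scatter)), and the morpholin-4-yl ring holds a second hetero atom, an oxygen, where the piperidin-1-yl ring holds none. The widest step in the set now lies between two amides rather than between an amide and the acid (a number 33.4 percentage points lower from compound 2 to compound 4 (beyond the scatter)), so the choice of amine part matters at least as much here as the replacement of the hydroxy itself.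

The compounds shown offer no evidence on why the morpholin-4-yl amide falls away from the piperidin-1-yl amide. Still open, as far as these compounds go, is where a 4-methylpiperazin-1-yl amide, a dimethylamino amide or a cyclopentylamino amide would fall on the carbonyl carbon of the shared core.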